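Aryl substituent swap on the shared core

The source may hold more compounds than are shown below. What is called first, only, known or untested is meant among the compounds shown, and "the series" means these compounds.

Compound 1 `O=[N+]([O-])c1cccc(CNc2cc(C(F)(F)F)cc3[nH]ncc23)c1` and compound 2 `O=C(O)CNc1cccc(CNc2cc(C(F)(F)F)cc3[nH]ncc23)c1` share one core and differ in a single group on the pendant ring. In an assay for inhibition of Indoleamine 2,3-dioxygenase 1 (Homo sapiens), with stated times of 10 min and 60 min (on this read-out lower numbers stand for stronger inhibition and higher numbers for weaker inhibition), compound 1 gives only a limit, > 100000 nM. In this assay compound 2 likewise gives only a limit, > 100000 nM. The step that the two limits leave unreadable from compound 1 to compound 2 is thus not readable; the limit of > 100000 nM in this assay, at which 2 of the 2 values shown sit, is all the measurements show. Compound 3 `FC(F)(F)c1cccc(CNc2cc(C(F)(F)F)cc3[nH]ncc23)c1` arises from compound 2 by trifluoromethyl in place of (carboxymethyl)amino on an aromatic carbon. Within the data shown here, no measured step bears on this change. Compound 3 is expected to stay at the limit, an expected step that the limit leaves unreadable from compound 2 to compound 3. The estimate for compound 3 is 150000 nM, between 30000 nM and 800000 nM.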

Compound 3, half-maximal inhibitory concentration: > 100000 nM
Compound 3 gave a limit, no number; the forecaster's own chance of this, stated with the estimate: 75%; the middle value does not contradict the limit.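

Among these compounds, no step among compound 1, compound 2 and compound 3 can be read, since each gives only a limit in this assay: the limit of > 100000 nM in this assay, at which 3 of the 3 values shown sit. Still open, from the compounds shown here alone, is whether any group on the pendant ring gives a readable value.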